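The source may hold more compounds than are shown below. What is called first, only, known or untested is meant among the compounds shown, and "the series" means these compounds.

Compound 1 `Oc1cccc(-c2cc(-c3cccc(C(F)(F)F)c3)cc(-c3ccccc3O)n2)c1` gives 6340 nM in a functional assay on T47D cells (Homo sapiens) for inhibition; a lower number here means a stronger inhibitor, a higher number a weaker inhibitor. Compound 2 `Oc1cccc(-c2cc(-c3ccc(C(F)(F)F)cc3)cc(-c3ccccc3O)n2)c1` differs from it in one place, (4-(trifluoromethyl)phenyl in place of 3-(trifluoromethyl)phenyl on an aromatic carbon). In this assay compound 2 reaches only a limit of the method, > 50000 nM. The change therefore made the step of an at least 7.8-fold higher number from compound 1 to compound 2 (0.89 log units; beyond the scatter), running into (the limit of > 50000 nM in this assay, at which 1 of the 3 values shown sits). Compound 3 `Oc1ccc(-c2cc(-c3cccc(C(F)(F)F)c3)cc(-c3cccc(O)c3)n2)cc1` differs from compound 1 by 4-hydroxyphenyl in place of 2-hydroxyphenyl on an aromatic carbon, and in this assay compound 3 gives 2630 nM, a step of a 2.4-fold lower number from compound 1 to compound 3 (0.38 log units; beyond the scatter). Compound 4 `Oc1ccc(-c2cc(-c3ccc(C(F)(F)F)cc3)cc(-c3cccc(O)c3)n2)cc1` awaits measurement and stands to compound 3 as compound 2 stands to compound 1, (4-(trifluoromethyl)phenyl in place of 3-(trifluoromethyl)phenyl on an aromatic carbon). The surroundings differ, the site being meta to a 3-hydroxyphenyl group and a 4-hydroxyphenyl group rather than to a 2-hydroxyphenyl group and a 3-hydroxyphenyl group, so this is the same kind of change, not the same one. The expected step is an 11-fold higher number from compound 3 to compound 4 (1.06 log units; beyond the scatter), resting on compound 1 and compound 2 with an at least 7.8-fold higher number from compound 1 to compound 2 (0.89 log units; beyond the scatter). Compound 4 is accordingly estimated at 30000 nM, between 8000 nM and 100000 nM.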

Compound 4, half-maximal inhibitory concentration: 2870 nM
Compound 4: the middle estimate sits 10-fold (1.02 log units) above what was measured; the measured number lies below the stated range.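

In this assay, the swap of 3-(trifluoromethyl)phenyl for 4-(trifluoromethyl)phenyl gave a 1.1-fold higher number from compound 3 to compound 4 (0.04 log units; within the scatter), so it did not carry over unchanged from the core of compound 1 to the core of compound 3: the same change on two cores in this assay, an at least 7.8-fold higher number (0.89 log units; beyond the scatter) from compound 1 to compound 2 and a 1.1-fold higher number (0.04 log units; within the scatter) from compound 3 to compound 4, at least 7.2-fold (0.85 log units) apart, beyond the scatter of two such steps The hydroxyphenyl change, seen with the 4-(trifluoromethyl)phenyl group, gave an at least 17-fold lower number from compound 2 to compound 4 (1.24 log units; beyond the scatter), and it too depended on its surroundings: the same change on two cores in this assay, a 2.4-fold lower number (0.38 log units; beyond the scatter) from compound 1 to compound 3 and an at least 17-fold lower number (1.24 log units; beyond the scatter) from compound 2 to compound 4, at least 7.2-fold (0.85 log units) apart, beyond the scatter of two such steps Compound 2 gives only a limit, > 50000 nM, and two cores cannot show how either change behaves on a further core.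

The compounds shown leave open how the swap behaves with other arrangements of the hydroxyphenyl groups. They also leave open whether a methoxy group or an amine in place of the hydroxyl, or a chlorine in place of trifluoromethyl, would show the same dependence on the core.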